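Carboxy in Place of Methylsulfonyl on the Shared Core

The compounds below may be only part of what the source reports. "The series", "measured", "known", "first", "only" and "open" are said of these compounds alone.

Two measured compounds share one core and differ only in the aryl group attached to it. Compound 1 `CCCS(=O)(=O)Nc1ccc(F)c(C(=O)c2n[nH]c3ncc(-c4ccc(Cl)c(Cl)c4)cc23)c1F` carries 3,4-dichlorophenyl, and in an assay for binding affinity to dual specificity mitogen-activated protein kinase kinase 4 (Homo sapiens), read by KINOMEscan, tested at 100 nM (a lower number here means a stronger effect, a higher number a weaker effect of the compound at the concentration tested), compound 1 gives 45%. Compound 2 `CCCS(=O)(=O)Nc1ccc(F)c(C(=O)c2n[nH]c3ncc(-c4ccc(S(C)(=O)=O)cc4)cc23)c1F` carries 4-(methylsulfonyl)phenyl, and in this assay compound 2 gives 1.5%, the lowest of the two numbers. For the measured compounds named here, the single measured step is a number 43.5 percentage points lower from compound 1 to compound 2 (beyond the scatter).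

Compound 3 `CCCS(=O)(=O)Nc1ccc(F)c(C(=O)c2n[nH]c3ncc(-c4ccc(C(=O)O)cc4)cc23)c1F` has not been measured. It differs from compound 2 in one place: carboxy in place of methylsulfonyl on an aromatic carbon. Going by the values given here, no measured step covers this exchange; the only step known, from compound 1 to compound 2, swaps the whole aryl group and does not involve carboxy, so it offers only a loose guide. Because compound 2 sits at 1.5%, there is little room for a further fall, and the change in compound 3 is expected to produce a step of a number 8.5 percentage points higher from compound 2 to compound 3 (within the scatter). The value of compound 3 in this assay is estimated at 10%, with a range from 1% to 50%.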

Compound 3, a percentage reported as activity, at one concentration (the size of the read-out at that concentration, not a potency): 0.1%
Beside the measured number, compound 3's estimate is 9.9 percentage points above it, and the stated range ends above it.
By their numbers in this assay, from the lowest: compounds 3 and 2 (each within the scatter of the next); then compound 1.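

In this assay the exchange of methylsulfonyl for carboxy gives a number 1.4 percentage points lower from compound 2 to compound 3 (within the scatter) and the two groups cannot be told apart at this position: the low number holds with the sulfur gone and a hydrogen-bond donor present in the new group. Replacing 3,4-dichlorophenyl with 4-carboxyphenyl gives a number 44.9 percentage points lower from compound 1 to compound 3 (beyond the scatter) and this stands alongside a number 43.5 percentage points lower from compound 1 to compound 2 (beyond the scatter) as a second large step, so the fall seen with 4-(methylsulfonyl)phenyl is no longer tied to that one group, while compound 1 remains the one clear exception among the three. No evidence bears on why these groups give the numbers they do.

Both compound 2 and compound 3 read close to the bottom of the scale at a single concentration, so any real difference in strength between methylsulfonyl and carboxy stays hidden. On these data alone, whether a primary amide, an amine or a methyl ester on the same aromatic carbon would also keep the number this low remains open, as does the question of which of the two chlorines in compound 1 matters for its higher number.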